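Fluoro in place of bromo in the series

A few compounds are considered here, and "the series" means these few. Any claim that something is new, unique, unknown or untested is made for them only; others in the source may bear on it.

In a functional assay on MCF7 cells (Homo sapiens) for antiproliferative activity, read by MTT assay, with a stated time of 48 h (a higher number here means a weaker inhibitor, a lower number a stronger inhibitor), compound 1 `Cc1ccc(-c2nn(-c3ccccc3)cc2CNc2ccc(F)cc2)cc1` gives 5880 nM and compound 2 `Brc1ccc(NCc2cn(-c3ccccc3)nc2-c2ccc(Br)cc2)cc1` gives 5000 nM. Among the measured compounds shown here, these are the only two numbers so far. They lie within the scatter of each other, so compound 2 cannot be ranked against compound 1.

Compound 3 `Fc1ccc(NCc2cn(-c3ccccc3)nc2-c2ccc(Br)cc2)cc1` comes from compound 2 by a single exchange: fluoro in place of bromo on an aromatic carbon. The exchange lies para to a large group and turns (4-bromophenyl)amino into (4-fluorophenyl)amino. For the measured compounds named here, no pair of measured compounds isolates this exchange, so its size cannot be read directly from the data. Going by the values given here, the only indirect guide is compound 1, which already carries the (4-fluorophenyl)amino group and gives 5880 nM, a value that offers no sign of a large shift.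

The expected step of a 1.1-fold higher number from compound 2 to compound 3 (0.04 log units; within the scatter) in this assay stays within the scatter, with no firm direction. The estimate for compound 3 is 5500 nM, with an expected range of 2500 nM to 11000 nM.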

Compound 3, half-maximal inhibitory concentration: 3960 nM
Compound 3: middle estimate off by 1.4-fold (0.14 log units), on the high side; low and high end bracket the measured number.
By their numbers in this assay, from the lowest: compounds 3, 2 and 1 (each within the scatter of the next).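

In this assay the exchange at this position can now be read directly: fluoro in place of bromo on an aromatic carbon, para to a large group, gives a 1.3-fold lower number from compound 2 to compound 3 (0.10 log units; within the scatter) and stays within the scatter, so (4-bromophenyl)amino and (4-fluorophenyl)amino cannot be told apart here. The second single exchange, bromo in place of methyl on an aromatic carbon with (4-fluorophenyl)amino kept, gives a 1.5-fold lower number from compound 1 to compound 3 (0.17 log units; within the scatter) and is also within the scatter, so neither of the two places changed so far has produced a step that can be separated from repeat measurement noise. No measurement beyond these antiproliferative numbers bears on the result.

Only bromo and fluoro have been seen at the first place and only bromo and methyl at the second, so these compounds do not show whether either place is insensitive in general or only to these small groups. A group of another kind there, such as an amine, a carboxylic acid or a longer chain, remains the open test of whether a step beyond the scatter can be found.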